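Propanolamine series: amine swap at the chain terminus

A few compounds are considered here, and "the series" means these few. Any claim that something is new, unique, unknown or untested is made for them only; others in the source may bear on it.

Among the compounds with values here, compound 2 `CC(C)N(CC(O)COc1ccccc1C(=O)CCc1ccccc1)C(C)C` gives 310 nM in a functional assay on CCRF-CEM/VCR-1000 cells (Homo sapiens) for inhibition (on this read-out lower numbers stand for stronger inhibition and higher numbers for weaker inhibition), and stands as the lower of the two numbers so far; its nearest neighbour, compound 1 `CC(C)N(CC(O)COc1ccc(O)cc1C(=O)CCc1ccccc1)C(C)C`, gives 1040 nM. Within the data shown here, the only measured step, a 3.4-fold lower number from compound 1 to compound 2 (0.53 log units; beyond the scatter), concerns the hydroxy on the aromatic ring and says nothing about the amine. Compound 3 `CN(C)CC(O)COc1ccccc1C(=O)CCc1ccccc1` differs from compound 2 at the other end of the molecule: dimethylamino in place of diisopropylamino on a saturated chain carbon, two bonds along the chain from an oxygen on a saturated carbon. Among the measured compounds shown here, no measured pair bears on this change, so the expectation rests on the change alone and carries a wide range. Compound 3 is estimated at 1500 nM in this assay, between 400 nM and 6000 nM, which means an expected step of a 4.8-fold higher number from compound 2 to compound 3 (0.68 log units; beyond the scatter); a result within the scatter of compound 2 would not be surprising.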

Compound 3, half-maximal inhibitory concentration: 2640 nM
Compound 3: middle estimate off by 1.8-fold (0.25 log units), on the low side, within the range that was stated.
By their numbers in this assay, from the lowest: compound 2; then compound 1; then compound 3.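

Working from this assay, the chain terminus now proves to be a position that moves the read-out: dimethylamino in place of diisopropylamino gives an 8.5-fold higher number from compound 2 to compound 3 (0.93 log units; beyond the scatter), a change that the earlier step at the aromatic hydroxy could not address. The two groups differ in heavy-atom count, while both carry no ring, no hydrogen-bond donor and no net charge, and each has the same single hydrogen-bond acceptor. Nothing on hand accounts for the step.

With only two amines in view, the compounds shown cannot say whether the number changes gradually or abruptly between these end points, and diethylamino would be the obvious intermediate to read. Also open, going by these compounds, is whether the hydroxy step seen with diisopropylamino carries over to the dimethylamino series.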